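The compounds below may be only part of what the source reports. "The series", "measured", "known", "first", "only" and "open" are said of these compounds alone.

Three compounds were measured in a physicochemical assay for lipophilicity; on this read-out higher numbers stand for higher lipophilicity and lower numbers for lower lipophilicity. Compound 1, `CCCCCCCCCC(=O)N[C@H](C(=O)Nc1ccn([C@H]2O[C@@H](CO)[C@H](O)[C@H]2O)c(=O)n1)C(C)C`, gives 0.78 in this assay. Compound 2, `CCCCCCCCCC(=O)N[C@@H](CCCNC(=N)N)C(=O)Nc1ccn([C@H]2O[C@@H](CO)[C@H](O)[C@H]2O)c(=O)n1`, gives 0.76 in this assay. Compound 3, `CCCCCCCCCCCCCCCCCC(=O)N[C@@H](CCCNC(=N)N)C(=O)Nc1ccn([C@H]2O[C@@H](CO)[C@H](O)[C@H]2O)c(=O)n1`, gives 0.61 in this assay. Compound 2 and compound 1 differ in one place: a group of 3 heavy atoms (3 carbon; no ring) in place of a group of 7 heavy atoms (4 carbon, 3 nitrogen; no ring), on a saturated chain carbon bound to an amide-type nitrogen and a carbonyl carbon. That change made a number 0.02 log units higher from compound 2 to compound 1 (within the scatter). Compound 2 and compound 3 also differ in one place, and that change made a number 0.15 log units lower from compound 2 to compound 3 (within the scatter). All three values lie within the usual scatter of one another, so no order among them can be read from these numbers.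

Compound 4, `CCCCCCCCCCCCCCCCCC(=O)N[C@H](C(=O)Nc1ccn([C@H]2O[C@@H](CO)[C@H](O)[C@H]2O)c(=O)n1)C(C)C`, has not yet been measured. It stands to compound 3 as compound 1 stands to compound 2: a group of 3 heavy atoms (3 carbon; no ring) in place of a group of 7 heavy atoms (4 carbon, 3 nitrogen; no ring), on a saturated chain carbon bound to an amide-type nitrogen and a carbonyl carbon. Among the compounds here this change occurs twice, and the place is worded the same in both cases, so it is the same change on two different cores. The two cores, that of compound 2 and that of compound 3, differ by octyl in place of hydrogen on a saturated chain carbon, nine bonds along the chain from a carbonyl carbon.

The step from compound 3 to compound 4 in this assay is expected to be a number 0.02 log units higher from compound 3 to compound 4 (within the scatter), beside the earlier one, because the same change gave a number 0.02 log units higher from compound 2 to compound 1 (within the scatter). Compound 4 is therefore estimated at 0.63, with a likely range from 0.3 to 0.96.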

Compound 4, partition coefficient: 0.91
The estimate for compound 4 lay 0.28 log units below the measured number; measured number inside the range.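

In this assay, putting isopropyl in place of the group of 7 heavy atoms, on a saturated chain carbon bound to an amide-type nitrogen and a carbonyl carbon, gives a number 0.30 log units higher from compound 3 to compound 4 (within the scatter) and on the other core gave a number 0.02 log units higher from compound 2 to compound 1 (within the scatter); octyl in place of hydrogen on a saturated chain carbon, nine bonds along the chain from a carbonyl carbon, gives a number 0.13 log units higher from compound 1 to compound 4 (within the scatter). With the change staying within the usual scatter on both cores, the pair agrees with carrying it from one core to the other only in this limited sense: neither core shows a step that can be told from repeat measurement, and this does not establish that the change has a real size of its own, or that such a size would be the same on both cores. Nothing available bears on why these steps came out as they did.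

The compounds shown leave open whether a primary amine or a carboxylic acid in that place, in place of isopropyl or the group of 7 heavy atoms, would give a step beyond the scatter on either core. They also leave open whether a chain longer than that of compound 3 or compound 4 would do so.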